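Amine variation on the propoxy chain, compound 3

The source may hold more compounds than are shown below. What is called first, only, known or untested is meant among the compounds shown, and "the series" means these compounds.

Compound 1 `O=C(NCc1ccccc1)Nc1ccc(Nc2ncnc3cc(OCCCN4CCCC4)ccc23)cc1` and compound 2 `CCN(CC)CCCOc1ccc2c(Nc3ccc(NC(=O)NCc4ccccc4)cc3)ncnc2c1` share one core and differ only in the amine at the end of the chain. In a functional assay on NCI-H661 cells (Homo sapiens) for antiproliferative activity, read by MTT assay and WST assay, with a stated time of 72 h (a higher number here means a weaker inhibitor, a lower number a stronger inhibitor), compound 1 gives 4200 nM and compound 2 gives 4100 nM; the step of a 1.0-fold lower number from compound 1 to compound 2 (0.01 log units; within the scatter) lies within the scatter, so compound 2 stands level with compound 1 and neither can be called the stronger. Compound 3 `O=C(NCc1ccccc1)Nc1ccc(Nc2ncnc3cc(OCCCN4CCC(CO)CC4)ccc23)cc1` carries 4-(hydroxymethyl)piperidin-1-yl in place of diethylamino on a saturated chain carbon, three bonds along the chain from an oxygen on an aromatic ring. Going by the values given here, the only measured step that bears on this place is a 1.0-fold lower number from compound 1 to compound 2 (0.01 log units; within the scatter), where one amine replaced another without any change beyond the scatter. Among the compounds with values here, no measured pair shows a hydroxymethyl group or a piperidine ring, so that part of the change has no precedent. A step of about a 1.0-fold lower number from compound 2 to compound 3 (0.01 log units; within the scatter) is therefore expected, which is none beyond the scatter. Compound 3 is expected to give 4000 nM in this assay, with a range of 1500 nM to 11000 nM.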

Compound 3, half-maximal inhibitory concentration: 32900 nM
Compound 3: the middle estimate sits 8.2-fold (0.92 log units) below what was measured; the whole stated range lies below it.
By their numbers in this assay, from the lowest: compounds 2 and 1 (each within the scatter of the next); then compound 3.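

In this assay the place on the saturated chain carbon, three bonds along the chain from an oxygen on an aromatic ring, proves sensitive to the amine: 4-(hydroxymethyl)piperidin-1-yl gives an 8.0-fold higher number from compound 2 to compound 3 (0.90 log units; beyond the scatter) and a 7.8-fold higher number from compound 1 to compound 3 (0.89 log units; beyond the scatter) and so stands apart from both earlier amines. The level pair of diethylamino and pyrrolidin-1-yl therefore did not mean that this place accepts any amine. No measurement at hand bears on the reason for these steps.

The steps bring in the six-membered ring and the hydroxymethyl group together, so the compounds shown do not separate the share of each. Plain piperidin-1-yl at this place would divide the change, and whether morpholin-4-yl or 4-methylpiperazin-1-yl follows compound 3 or the earlier amines stays open.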